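This account rests on a few compounds, and the source may have more. Where it says the series, first, only, none or still open, it means among the compounds named here.

Working notes on the series.

For the measured compounds named here, compound 1, `O=C(Nc1cccc(-c2nc3ccccc3s2)c1)c1cc([N+](=O)[O-])ccc1Cl`, is the only member with a numerical result in an ADME assay for permeability, using PAMPA, at pH 7.4 (on this read-out lower numbers stand for lower permeability and higher numbers for higher permeability), where compound 1 gives 12 10^-6 cm/s. Compound 2, `O=C(Nc1cc(-c2nc3ccccc3s2)ccc1Cl)c1cc([N+](=O)[O-])ccc1Cl`, gives no number in this assay, its entry reading "below limit of detection" (no number reported). Going by the values given here, no step between two measured compounds can therefore be computed, and compound 1 stands as the single reference point for the read-out.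

Compound 3, `O=C(Nc1cccc(-c2nc3ccccc3[nH]2)c1)c1cc([N+](=O)[O-])ccc1Cl`, has not yet been measured in this assay. Compared with compound 1 the change is 1H-benzimidazol-2-yl in place of 1,3-benzothiazol-2-yl on an aromatic carbon. The substitution leaves the shared core, the amide and the nitro- and chloro-bearing ring untouched, so the comparison isolates one ring system against another at the same aromatic carbon.

With only compound 1 as anchor, the expectation for compound 3 in this assay is a downward step of moderate size, beyond the usual scatter, corresponding to a 2.4-fold lower number from compound 1 to compound 3 (0.38 log units; beyond the scatter). The estimated value for compound 3 is 5 10^-6 cm/s, with the likely range running from 1.5 10^-6 cm/s to 12 10^-6 cm/s, and the measurement is awaited.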

Compound 3, apparent permeability: 352 10^-6 cm/s
Compound 3: middle estimate off by 70-fold (1.85 log units), on the low side; measured number outside the range, above it.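

At this aromatic carbon, 1H-benzimidazol-2-yl in place of 1,3-benzothiazol-2-yl gives a 29-fold higher number from compound 1 to compound 3 (1.47 log units; beyond the scatter) in this assay, which shows that the read-out is highly sensitive to the identity of the group held here, even though both groups contain one five-membered and one six-membered aromatic ring. The change exchanges sulfur for nitrogen, and the counts move from 0 hydrogen-bond donors and 2 hydrogen-bond acceptors to 1 hydrogen-bond donor and 1 hydrogen-bond acceptor, but this single pair cannot separate those differences from one another. No measurement in hand accounts for the size of this step.

The compounds shown leave open whether a similar number would be seen with 1-methyl-1H-benzimidazol-2-yl or 1,3-benzoxazol-2-yl on the same carbon, which would help separate the ring nitrogen hydrogen from the loss of sulfur. They also leave open whether the step carries over to the chlorine-bearing core of compound 2, whose entry in this assay has no number.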